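The source may report more compounds than this note shows. Statements on the series, on what has been measured and on what is new or still open speak of the compounds shown alone.

In an ADME assay on MT4 cells (Homo sapiens) for cytotoxicity, read by MTT assay, with a stated time of 5 days (on this read-out lower numbers stand for higher toxicity in this test and higher numbers for lower toxicity in this test), compound 1 `Cc1ccc(CN2C(=O)N(Cc3ccccc3)S(=O)(=O)n3cccc32)cc1` gives 241000 nM.
In this assay compound 2 `N#Cc1ccccc1CN1C(=O)N(Cc2ccccc2)S(=O)(=O)n2cccc21` reaches only a limit of the test, > 318000 nM.
In this assay compound 3 `O=C1N(Cc2ccc(Cl)cc2Cl)c2cccn2S(=O)(=O)N1Cc1ccccc1` gives 218000 nM.

Compound 2 thus stands at a limit rather than a number, (the limit of > 318000 nM in this assay, at which 1 of the 3 values shown sits). Compound 4 `N#Cc1ccccc1CN1C(=O)N(Cc2cccc(Cl)c2)S(=O)(=O)n2cccc21` arises from compound 2 by chloro in place of hydrogen on an aromatic carbon. Every measured step alters a different benzyl: an at least 1.3-fold higher number from compound 1 to compound 2 (0.12 log units; that floor lies within the scatter) and an at least 1.4-fold lower number from compound 2 to compound 3 (0.16 log units; that floor lies within the scatter) each involve compound 2, and a 1.1-fold lower number from compound 1 to compound 3 (0.04 log units; within the scatter) links the other two, all within the scatter, so none of them touches the change that leads to compound 4. With three values so close, no step beyond the scatter is expected for compound 4, whose estimated value in this assay is 300000 nM, between 150000 nM and 600000 nM. That estimate corresponds to an at least 1.0-fold lower number from compound 2 to compound 4 (0.02 log units; that floor lies within the scatter).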

Compound 4, half-maximal cytotoxic concentration: > 293000 nM
Compound 4 ended at the assay's limit (the forecaster's own chance of this, stated with the estimate: 50%); the middle value lies beyond the limit too.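

In this assay, going by these compounds alone, compound 2 and compound 4 both stand at limits of the test, so no step between them can be read. The compounds shown leave open whether 3-chlorobenzyl in place of benzyl changes the half-maximal cytotoxic concentration at all.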